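This account rests on a few compounds, and the source may have more. Where it says the series, first, only, none or still open, it means among the compounds named here.

Measured so far in a functional assay on MCF7 cells (Homo sapiens) for cytotoxicity, read by MTT assay, with a stated time of 48 h; on this read-out lower numbers stand for stronger inhibition and higher numbers for weaker inhibition:
Compound 1 `O=C(c1cn(-c2ccccc2)nc1-c1cccnc1)N1CCC(Cc2ccccc2)CC1` gives 32200 nM.
Compound 2 `COc1ccc(OC(=O)c2cn(-c3ccccc3)nc2-c2cccnc2)cc1` gives only a limit of the assay, > 100000 nM.
Compound 3 `CC(C)c1cccc(OC(=O)c2cn(-c3ccccc3)nc2-c2cccnc2)c1` gives 75500 nM.

Compound 3 stands at the higher of the two numbers in this assay; compound 1 gives the lower number, and that gap lies beyond the usual scatter. Compound 2 sits at the limit of > 100000 nM in this assay, at which 1 of the 3 values shown sits.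

The step to compound 4 `CC(C)(C)c1ccc(OC(=O)c2cn(-c3ccccc3)nc2-c2cccnc2)cc1` is 4-(tert-butyl)phenyl in place of 3-isopropylphenyl on an oxygen next to a carbonyl group. For the measured compounds named here, the only measured step at this oxygen is an at least 1.3-fold lower number from compound 2 to compound 3 (0.12 log units; that floor lies within the scatter), which starts from a limit and whose floor lies within the scatter, so it tells little about the size of change that a new aryl group on this oxygen brings. Both compounds carrying an aryl group on this oxygen, compound 2 and compound 3, give weak numbers in this assay. For compound 4 no shift beyond the scatter is expected, and the estimated step is a 1.2-fold higher number from compound 3 to compound 4 (0.08 log units; within the scatter). Compound 4 is expected to give about 90000 nM in this assay, within 40000 nM to 200000 nM, with a fair chance that only a limit is reported.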

Compound 4, half-maximal inhibitory concentration: > 100000 nM
Compound 4: only a limit was reported (the forecaster's own chance of this, stated with the estimate: 40%); at least 1.1-fold (0.04 log units) between middle value and limit.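

In this assay, the change to 4-(tert-butyl)phenyl on this oxygen gives an at least 1.3-fold higher number from compound 3 to compound 4 (0.12 log units; that floor lies within the scatter), so this exchange of one alkyl-substituted phenyl group for another shows no shift that can be told from the scatter. The step from compound 2 to compound 4 cannot be read, as both values are limits. Compound 4 is reported only as a limit, and so two of the three compounds with an aryl group on this oxygen now sit at the same end of the assay's range: the limit of > 100000 nM in this assay, at which 2 of the 4 values shown sit.

On these data alone, whether an amine or a carboxylic acid on the aryl group at this oxygen would give a clearly lower number than compound 3 with 75500 nM stays open. As far as these compounds go, how far compound 2 and compound 4 lie beyond the limit also stays open.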